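The source may hold more compounds than are shown below. What is called first, only, known or untested is meant among the compounds shown, and "the series" means these compounds.

Measured compounds, cytotoxicity:
compound 1 `COc1cc2ncnc(NNC(=S)NC(=O)c3ccccc3C)c2cc1OC`: 11400 nM in a functional assay on KB cells (Homo sapiens) for cytotoxicity, read by MTT assay, with a stated time of 72 h; a lower number here means a stronger inhibitor, a higher number a weaker inhibitor
compound 2 `COc1cc2ncnc(NNC(=S)NC(=O)c3ccc(F)cc3)c2cc1OC`: 4530 nM in this assay
compound 3 `COc1cc2ncnc(NNC(=S)NC(=O)c3ccccc3)c2cc1OC`: 3770 nM in this assay

Compound 3 has the lowest of the three numbers, though compound 2 sits within the scatter of it; only compound 1 stands clearly apart, with a 3.0-fold lower number from compound 1 to compound 3 (0.48 log units; beyond the scatter).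

Compound 4 `COc1cc2ncnc(NNC(=S)NC(=O)c3ccccc3Cl)c2cc1OC` differs from compound 3 in one place: chloro in place of hydrogen on an aromatic carbon. The step that bears most on it is the removal of the methyl on the same aromatic carbon, a 3.0-fold lower number from compound 1 to compound 3 (0.48 log units; beyond the scatter), which ran in compound 3's favour; the ring change a 2.5-fold lower number from compound 1 to compound 2 (0.40 log units; beyond the scatter) points the same way. A group entering at that position is therefore expected to push the number up, by a modest step, a 2.0-fold higher number from compound 3 to compound 4 (0.30 log units; within the scatter). Compound 4 is estimated at 7500 nM, within 3500 nM to 16000 nM.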

Compound 4, half-maximal inhibitory concentration: 3560 nM
Estimate against measurement, compound 4: 2.1-fold (0.32 log units) above; measured number inside the range.
By their numbers in this assay, from the lowest: compounds 4, 3 and 2 (each within the scatter of the next); then compound 1.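

In (this assay), chloro on this aromatic carbon, ortho to a large group, cannot be told apart from hydrogen (a 1.1-fold lower number from compound 3 to compound 4 (0.02 log units; within the scatter)). A group at this place therefore does not always raise the number as methyl does, and chloro in place of methyl gives a step beyond the scatter (a 3.2-fold lower number from compound 1 to compound 4 (0.51 log units; beyond the scatter)), while 2-chlorophenyl in place of 4-fluorophenyl stays within it (a 1.3-fold lower number from compound 2 to compound 4 (0.10 log units; within the scatter)). Nothing available explains why chloro and methyl differ here.

Open, on these data alone, is whether bromo, an amine or a longer chain at this carbon would stay level with hydrogen or track methyl.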